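Swapping the pyridine substituent on the weakest compound

The compounds below may be only part of what the source reports. "The series", "measured", "known", "first", "only" and "open" are said of these compounds alone.

Compound 1 `CC1CN(S(=O)(=O)C[C@]23CC[C@H](CC2=O)C3(C)C)CCN1c1ccc(C(F)(F)F)cn1`: 316 nM
Compound 2 `CC1(C)[C@@H]2CC[C@@]1(CS(=O)(=O)N1CCN(c3cc(C(F)(F)F)ccn3)CC1)C(=O)C2`: 25100 nM
Compound 3 `C[C@@H]1CN(S(=O)(=O)C[C@]23CC[C@H](CC2=O)C3(C)C)CCN1c1ccc(C(F)(F)F)cn1`: 501 nM

All three were tested in a functional assay on CHO-K1 cells for antagonist activity at C-X-C chemokine receptor type 3 (Homo sapiens), read by FLIPR and calcium flux; a lower number here means a stronger inhibitor, a higher number a weaker inhibitor. Compound 2 stands at the high end of the three numbers: its value lies well above those of compound 3 and compound 1, both gaps beyond the scatter. Compound 4 `CC1(C)[C@@H]2CC[C@@]1(CS(=O)(=O)N1CCN(c3ccc([N+](=O)[O-])cn3)CC1)C(=O)C2` is not yet measured. It differs from compound 2 by one change, (5-nitropyridin-2-yl in place of 4-(trifluoromethyl)pyridin-2-yl on an amine nitrogen in a ring).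

Within the data shown here, only one measured step exists, a 1.6-fold higher number from compound 1 to compound 3 (0.20 log units; within the scatter), and it concerns the ring carbon whose drawing differs, as noted in the fact that one of compounds 1 and 3 is drawn with a defined configuration and the other without, at the place where they differ; it says nothing about the pyridine substituent. Compounds 1 and 3 differ from compound 2 in two places at once, so their values show only that large differences are possible in this series, not what this particular change does. Among the measured compounds shown here, no measured step therefore bears on the change from compound 2 to compound 4, and the direction is open.

Compound 4 is expected to give 10000 nM, within the range 1000 nM to 40000 nM, as a wide-uncertainty estimate. This means an expected step of a 2.5-fold lower number from compound 2 to compound 4 (0.40 log units; beyond the scatter), with no firm basis for a direction beyond the scatter.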

Compound 4, half-maximal inhibitory concentration: > 31600 nM
Compound 4 gave a limit, no number (the forecaster's own chance of this, stated with the estimate: 15%); middle value at least 3.1-fold (0.49 log units) from the limit.
By their numbers in this assay, from the lowest: compounds 1 and 3 (each within the scatter of the next); then compound 2. At a limit, above all of these: compound 4.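

In this assay, compound 4 gives > 31600 nM, which is a limit of the assay and not a number. Among these compounds, this is the first measured step for the group on this ring nitrogen, and it reads an at least 1.2-fold higher number from compound 2 to compound 4 (0.10 log units; that floor lies within the scatter); 5-nitropyridin-2-yl in place of 4-(trifluoromethyl)pyridin-2-yl therefore brings no lower number, although the floor of the step does not by itself separate the two compounds. How far compound 4 actually lies from compound 2 cannot be read from this result: the limit of > 31600 nM in this assay, at which 1 of the 4 values shown sits.

The compounds shown leave open whether another group on this pyridine, such as an amine, a nitrile or a carboxylic acid, would give a lower number than compound 2. They also do not separate the effect of the group itself from that of where it sits on the pyridine, as the two names differ in both.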